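This account rests on a few compounds, and the source may have more. Where it says the series, first, only, none or still open, it means among the compounds named here.

In a functional assay on MCF7 cells (Homo sapiens) for cytotoxicity, read by CCK-8 assay, with a stated time of 72 h (a higher number here means a weaker inhibitor, a lower number a stronger inhibitor), compound 3 `C=CCn1c(=O)/c(=C\c2ccccc2F)[nH]c(=O)/c1=C\c1ccccc1OC` gives 23000 nM, the only numerical result among these compounds. Compound 1 `COc1ccccc1/C=c1/[nH]c(=O)/c(=C\c2ccccc2OC)[nH]c1=O` is recorded in this assay as "not active" (no number reported), and compound 2 `C=CCn1c(=O)/c(=C\c2cccc(Br)c2)[nH]c(=O)/c1=C\c1cccc(Br)c1` likewise as "not active" (no number reported), so no numerical comparison to compound 3 can be drawn from either. Compound 4 `C=CCn1c(=O)/c(=C\c2cc(Br)ccc2F)[nH]c(=O)/c1=C\c1ccccc1OC` differs from compound 3 by bromo in place of hydrogen on an aromatic carbon. Going by the values given here, no measured pair shows the effect of such a change, and compound 2, which carries bromo groups on both rings, gives no number at all. The step from compound 3 to compound 4 is therefore expected to stay within the usual scatter, a 1.3-fold lower number from compound 3 to compound 4 (0.11 log units; within the scatter). Compound 4 is estimated at 18000 nM, with a likely range from 6000 nM to 55000 nM.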

Compound 4, half-maximal inhibitory concentration: 28100 nM
The estimate for compound 4 lay 1.6-fold (0.19 log units) below the measured number; the range from low to high includes it.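

In this assay bromo in place of hydrogen, on the aromatic carbon para to the fluoro group, gives a 1.2-fold higher number from compound 3 to compound 4 (0.09 log units; within the scatter) and so leaves the number within the scatter. Going by these compounds alone, this is the first measured step at this position, and it shows that a single bromine atom here leaves the cytotoxicity reading where it was, in the weak range of compound 3. Nothing measured on these compounds accounts for this result. Still open, going by these compounds, is whether an amine or a carboxylic acid on this same aromatic carbon would move the number beyond the scatter.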